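Replacing an oxazole with a tetrazolylmethyl arm

A few compounds are considered here, and "the series" means these few. Any claim that something is new, unique, unknown or untested is made for them only; others in the source may bear on it.

Three compounds from this series have been run through an ADME assay on microsomes from liver (Mus musculus) for metabolic stability; on this read-out lower numbers stand for a shorter-lived compound and higher numbers for a longer-lived compound. Compound 1 `CC(C)C(c1ncco1)c1ccc(-c2ccc3cccc(F)c3c2)[nH]c1=O` carries a 1,3-oxazol-2-yl group on its side chain, and in this assay compound 1 gives 0.08 h, the lowest of the two plain numbers. Compound 3 `CCC(CC)(c1nnc[nH]1)c1ccc(-c2ccc3cccc(F)c3c2)[nH]c1=O` reaches 0.447 h in this assay, a gap from compound 1 that lies beyond the usual scatter. Compound 2 `CCn1ncc2c(F)cc(-c3ccc(C(CC)(CC)c4nncn4C)c(=O)[nH]3)cc21` sits at the limit of this assay, giving > 3 h, a limit rather than a number (the limit of > 3 h in this assay, at which 1 of the 3 values shown sits). Compound 4 `CC(C)C(Cc1nnn[nH]1)c1ccc(-c2ccc3cccc(F)c3c2)[nH]c1=O` has not yet been measured. It differs from compound 1 in one place: (1H-tetrazol-5-yl)methyl in place of 1,3-oxazol-2-yl on a saturated chain carbon bound to an aromatic carbon and a saturated chain carbon. Going by the values given here, no measured pair shows this exact change, so the expectation rests on the spread of the numbers seen so far. Compound 4 is expected to move upward from compound 1 by the step of a 3.8-fold higher number from compound 1 to compound 4 (0.57 log units; beyond the scatter) in this assay, beyond the scatter but well short of the limit. The estimated half-life for compound 4 is 0.3 h, with a likely range from 0.08 h to 1.2 h.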

Compound 4, half-life: 0.853 h
The estimate for compound 4 lay 2.8-fold (0.45 log units) below the measured number; the range from low to high includes it.
By their numbers in this assay, from the lowest: compound 1; then compounds 3 and 4 (each within the scatter of the next). At a limit, above all of these: compound 2.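

On a saturated chain carbon bound to an aromatic carbon and a saturated chain carbon, (1H-tetrazol-5-yl)methyl in place of 1,3-oxazol-2-yl gives in this assay an 11-fold higher number from compound 1 to compound 4 (1.03 log units; beyond the scatter), a large step. Going by these compounds alone, this is the first measured pair that differs in one place, and it shows that the group at this position can, with the rest of the molecule unchanged, shift the half-life well beyond the scatter. No measurement shown here speaks to what lies behind this step.

The change swaps the ring and brings in the methyl link at once, so the compounds shown cannot tell which of the two goes with the step. As far as these compounds go, how a 1,3-oxazol-2-ylmethyl arm, a 1H-tetrazol-5-yl group without the methyl, or a carboxylic acid would fare at this place stays open.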